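Adding a chain to the ethynyl of compound 2

This account rests on a few compounds, and the source may have more. Where it says the series, first, only, none or still open, it means among the compounds named here.

Values in a functional assay on L1210 cells (Mus musculus) for inhibition (a higher number here means a weaker inhibitor, a lower number a stronger inhibitor), so far:
- compound 1 `CCCCC#Cc1c(C(N)=O)ncn1C1O[C@H](CO)[C@@H](O)[C@H]1O` gives 2.29 ug/mL
- compound 2 `C#Cc1c(C#N)ncn1C1O[C@H](CO)[C@@H](O)[C@H]1O` gives 1.9 ug/mL

Compound 2 and compound 1 stand within the scatter of each other, so the numbers do not separate them. Among the compounds with values here, the two differ in more than one place, and no single-change step is available as a guide. Compound 3 `N#Cc1ncn(C2O[C@H](CO)[C@@H](O)[C@H]2O)c1C#CCCO` differs from compound 2 by 2-hydroxyethyl in place of hydrogen on a triple-bonded carbon and so carries 2-hydroxyethyl in place of hydrogen on a triple-bonded carbon. Compound 1 also bears a chain on its triple bond and gives 2.29 ug/mL in this assay but differs elsewhere too, so it offers only weak support. The expected change a 3.2-fold higher number from compound 2 to compound 3 (0.50 log units; beyond the scatter) is a moderate one towards a weaker inhibitor, beyond the scatter but with wide uncertainty. In this assay compound 3 is estimated at 6 ug/mL with an expected range of 1.5 ug/mL to 40 ug/mL for this measurement.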

Compound 3, half-maximal inhibitory concentration: 3.3 ug/mL
Compound 3: the middle estimate sits 1.8-fold (0.26 log units) above what was measured; the measured number falls inside the stated range.
By their numbers in this assay, from the lowest: compounds 2, 1 and 3 (each within the scatter of the next).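

In this assay, within the data shown here, 2-hydroxyethyl in place of hydrogen on a triple-bonded carbon gives a 1.7-fold higher number from compound 2 to compound 3 (0.24 log units; within the scatter), the first single-change step. At this position, ethynyl and 4-hydroxybut-1-yn-1-yl therefore cannot be told apart by this read-out, so this change alone gives no measurable separation. Nothing measured on these compounds offers an explanation for this result.

Still open, as far as these compounds go, is whether a longer chain, an amine or a carboxylic acid on the same triple-bonded carbon would move the number beyond the scatter from that of compound 2. The chain on compound 1 also cannot be compared directly with 2-hydroxyethyl, since compound 1 differs from compound 3 in more than one place.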